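From compound 3 to compound 4: adding a cyano group

A few compounds are considered here, and "the series" means these few. Any claim that something is new, unique, unknown or untested is made for them only; others in the source may bear on it.

Compound 1 `N#CCC(=O)Nc1ccn(-c2ccc(Cl)c(Cl)c2)n1`: 34000 nM
Compound 2 `NC1=NN(c2ccc(Cl)c(Cl)c2)CC1`: 69000 nM
Compound 3 `CC(=O)NC1=NN(c2ccc(Cl)c(Cl)c2)CC1`: 31000 nM

In a physicochemical assay for solubility, measured as kinetic solubility, with a stated time of 1 h, at pH 7.4 (a lower number here means a less soluble compound, a higher number a more soluble compound), compound 3 gives 31000 nM, within the usual scatter of compound 1. Compound 2 stands clearly apart at 69000 nM. Among the compounds with values here, the only measured step here is modest: a 2.2-fold lower number from compound 2 to compound 3 (0.35 log units; beyond the scatter), with acetyl in place of hydrogen on an amine nitrogen.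

Compound 4 `N#CCC(=O)NC1=NN(c2ccc(Cl)c(Cl)c2)CC1` takes compound 3 one change further: cyano in place of hydrogen on a saturated chain carbon bound to a carbonyl carbon. That is cyano in place of hydrogen on a saturated chain carbon bound to a carbonyl carbon, turning acetyl into (cyanomethyl)carbonyl.

Within the data shown here, no measured pair shows this change directly, so the acetyl step offers only a rough sense of scale. Compound 1, at 34000 nM, carries the same ((cyanomethyl)carbonyl)amino group on a different core. No shift beyond the scatter is therefore expected in this assay, and the estimated step is a 1.0-fold higher number from compound 3 to compound 4 (0.01 log units; within the scatter). For compound 4 the estimated value is 32000 nM, with an expected range from 15000 nM to 65000 nM.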

Compound 4, solubility: 202000 nM
The estimate for compound 4 lay 6.3-fold (0.80 log units) below the measured number; the measured number lies above the stated range.
By their numbers in this assay, from the lowest: compounds 3 and 1 (each within the scatter of the next); then compound 2; then compound 4.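

At a saturated chain carbon bound to a carbonyl carbon, cyano in place of hydrogen gives a clear rise in this assay, with a 6.5-fold higher number from compound 3 to compound 4 (0.81 log units; beyond the scatter). Placing a carbonyl group on the amine nitrogen therefore does not always bring the number down: acetyl gave a 2.2-fold lower number from compound 2 to compound 3 (0.35 log units; beyond the scatter), whereas (cyanomethyl)carbonyl gives a 2.9-fold higher number from compound 2 to compound 4 (0.47 log units; beyond the scatter). Compound 1 carries the same ((cyanomethyl)carbonyl)amino group on a different core and gives 34000 nM, so the high number of compound 4 belongs to the group and core together, not to the group alone.

Nothing measured here gives a reason for this rise. On these data alone, it also remains open whether the rise is particular to the cyano group, or whether a hydroxyl group, a carboxylic acid or a longer chain ending in a nitrile at that carbon would give a similar number.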